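The compounds below may be only part of what the source reports. "The series", "measured", "known", "first", "only" and "open" are said of these compounds alone.

Compound 1 `COc1cc(NC(C)CCCNC(=O)NNC(=O)NCCCCCO)c2ncccc2c1`: 170000 nM
Compound 2 `COc1ccc(/C(=N/NC(=O)NCCCC(C)Nc2cc(OC)cc3cccnc23)c2ccccc2)cc1`: 10000 nM

In a functional assay on CCRF-CEM cells (Homo sapiens) for inhibition, read by MTT assay, with a stated time of 4 days (on this read-out lower numbers stand for stronger inhibition and higher numbers for weaker inhibition), compound 1 holds the higher of the two numbers at 170000 nM, which marks it as the weaker inhibitor. Among the compounds with values here, its only neighbour, compound 2, gives 10000 nM, a gap beyond the scatter. Compound 3 `COc1cc(NC(C)CCCNC(=O)NNC(=O)NCCCO)c2ncccc2c1` has not yet been measured. It differs from compound 1 in one place: hydroxy in place of 2-hydroxyethyl on a saturated chain carbon, three bonds along the chain from an amide-type nitrogen. This is hydroxy in place of 2-hydroxyethyl on a saturated chain carbon, three bonds along the chain from an amide-type nitrogen. Cut one bond further out, the same difference reads 5-hydroxypentyl to 3-hydroxypropyl. Within the data shown here, no measured pair of compounds differing in one place is available, so the expectation rests on the structural change alone. The expected 1.2-fold lower number from compound 1 to compound 3 (0.08 log units; within the scatter) is no change beyond the scatter in this assay. Compound 3 is estimated at 140000 nM, with an expected range of 60000 nM to 320000 nM.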

Compound 3, half-maximal inhibitory concentration: > 250000 nM
Compound 3 gave a limit, no number; the forecaster's own chance of this, stated with the estimate: 15%; middle value at least 1.7-fold (0.25 log units) from the limit.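

In this assay compound 3 gives > 250000 nM, which is a limit of the assay and not a number. Going from 5-hydroxypentyl to 3-hydroxypropyl, on a saturated chain carbon, three bonds along the chain from an amide-type nitrogen, gives an at least 1.4-fold higher number from compound 1 to compound 3 (0.16 log units; that floor lies within the scatter), so this shortening shows no sign of stronger inhibition at this position. The size of the step stays unknown, since only its floor can be read and the true value of compound 3 lies out of reach of the read-out: the limit of > 250000 nM in this assay, at which 1 of the 3 values shown sits.

The compounds shown leave open whether the terminal hydroxy or the length of the chain matters more at this position. An amine or a carboxylic acid at the chain end, or a chain longer than 5-hydroxypentyl, would be needed to separate the two.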